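The source may hold more compounds than are shown below. What is called first, only, known or untested is meant among the compounds shown, and "the series" means these compounds.

Three compounds have been measured in a functional assay on MCF7 cells (Homo sapiens) for cytotoxicity, read by MTT assay, with a stated time of 48 h (on this read-out lower numbers stand for stronger inhibition and higher numbers for weaker inhibition), so far:

- compound 1 `Cc1ccc(-c2nnc(SCCn3c([N+](=O)[O-])cnc3C)o2)cc1` gives 15500 nM
- compound 2 `COc1ccccc1-c1nnc(SCCn2c([N+](=O)[O-])cnc2C)o1` gives 10800 nM
- compound 3 `Cc1ncc([N+](=O)[O-])n1CCSc1nnc(-c2ccccc2F)o1` gives 20500 nM

Compound 3, at 20500 nM, is not set apart from the other two. Its links to them are a 1.3-fold higher number from compound 1 to compound 3 (0.12 log units; within the scatter) and a 1.9-fold higher number from compound 2 to compound 3 (0.28 log units; within the scatter), and neither goes beyond the scatter. The next compound is compound 4 `Cc1ccc(-c2nnc(SCCn3c([N+](=O)[O-])cnc3C)o2)c(O)c1`, which differs from compound 3 at one place: 2-hydroxy-4-methylphenyl in place of 2-fluorophenyl on an aromatic carbon. In words, this is 2-hydroxy-4-methylphenyl in place of 2-fluorophenyl on an aromatic carbon of the five-membered aromatic ring.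

Among the measured compounds shown here, all the measured steps exchange the group at this place. Besides the two above, there is a 1.4-fold lower number from compound 1 to compound 2 (0.16 log units; within the scatter), so the whole set of changes has so far moved the number only within the scatter. For the measured compounds named here, none of the measured compounds carries a hydroxy group, so the data offer no direct step for it, and a larger move in either direction cannot be ruled out. Little movement is therefore expected in this assay, with a slight lean toward a lower number. The expected step is a 1.5-fold lower number from compound 3 to compound 4 (0.17 log units; within the scatter), which would lie within the scatter. For compound 4 the estimated value is 14000 nM, with an expected span from 6000 nM to 30000 nM.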

Compound 4, half-maximal inhibitory concentration: 23500 nM
Compound 4: the middle estimate sits 1.7-fold (0.22 log units) below what was measured, within the range that was stated.
By their numbers in this assay, from the lowest: compounds 2, 1, 3 and 4 (each within the scatter of the next, the first and the last beyond it).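

Among the compounds shown here, compound 4 is the only compound here that carries a hydroxy group, and in this assay adding it to the 4-methylphenyl group gives a 1.5-fold higher number from compound 1 to compound 4 (0.18 log units; within the scatter), so this addition leaves the number within the scatter. For the compounds shown here, exchanging the 2-fluorophenyl group gives a similarly small result, a 1.1-fold higher number from compound 3 to compound 4 (0.06 log units; within the scatter), whereas 2-hydroxy-4-methylphenyl in place of 2-methoxyphenyl gives a 2.2-fold higher number from compound 2 to compound 4 (0.34 log units; beyond the scatter), the only step in the set that passes beyond the scatter, and only modestly. This position can therefore shift the number slightly, but a hydrogen-bond donor on the aromatic ring brings no gain in this set, and nothing available bears on the cause of these small moves.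

On these data alone, all four compounds keep a substituted six-membered aromatic ring of carbon at this place, so it remains open what an amine or a carboxylic acid on that ring would do, or a longer alkyl chain in place of the ring. As far as these compounds go, it also remains open whether these small differences would hold on another cell line.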